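Chlorothiophene for methylthiophene on a second pyridine core

A few compounds are considered here, and "the series" means these few. Any claim that something is new, unique, unknown or untested is made for them only; others in the source may bear on it.

Measured compounds:
Compound 1, `Cc1ccsc1-c1cc(-c2ccco2)cc(-c2ccc(Cl)cc2)n1`, 890 nM
Compound 2, `Clc1ccc(-c2cc(-c3ccco3)cc(-c3ccc(Cl)s3)n2)cc1`, 1520 nM
Compound 3, `Cc1ccsc1-c1cc(-c2ccc(Cl)o2)cc(-c2ccco2)n1`, 5570 nM

The three measured compounds were tested in a functional assay on MCF7 cells (Homo sapiens) for cytotoxicity, read by ELISA, with a stated time of 4 days; a higher number here means a weaker inhibitor, a lower number a stronger inhibitor. Compound 1 gives 890 nM and compound 2 gives 1520 nM; between them stands one change, (5-chlorothiophen-2-yl in place of 3-methylthiophen-2-yl on an aromatic carbon), and the step it made was a 1.7-fold higher number from compound 1 to compound 2 (0.23 log units; within the scatter). Compound 3 gives 5570 nM, the highest of the three numbers, beyond the scatter from both compound 1 and compound 2. How the core of compound 3 differs from the core of compound 1 is not broken down here.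

Compound 4, `Clc1ccc(-c2cc(-c3ccco3)nc(-c3ccc(Cl)s3)c2)o1`, has not yet been measured in this assay. It arises from compound 3 by 5-chlorothiophen-2-yl in place of 3-methylthiophen-2-yl on an aromatic carbon. Among the compounds with values here, this is the same kind of change as the one from compound 1 to compound 2, not the same: in compound 1 the place is meta to a 4-chlorophenyl group, in compound 3 it is meta to a 5-chlorofuran-2-yl group. Because a 1.7-fold higher number from compound 1 to compound 2 (0.23 log units; within the scatter) stayed within the scatter, the step for compound 4 is expected to be small, a 1.4-fold higher number from compound 3 to compound 4 (0.16 log units; within the scatter). Compound 4 is therefore estimated at 8000 nM, expected between 3000 nM and 20000 nM.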

Compound 4, half-maximal inhibitory concentration: 16900 nM
Estimate against measurement, compound 4: 2.1-fold (0.32 log units) below, and the stated range covers the measured number.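

In this assay, putting 5-chlorothiophen-2-yl in place of 3-methylthiophen-2-yl on the second core gave a 3.0-fold higher number from compound 3 to compound 4 (0.48 log units; beyond the scatter), a step beyond the scatter, whereas the earlier step on the first core stayed within it. Set side by side, the two steps are no further apart than two such steps can be expected to scatter, so the data give no sign that the change behaves differently on the two cores: the same change on two cores in this assay, a 1.7-fold higher number (0.23 log units; within the scatter) from compound 1 to compound 2 and a 3.0-fold higher number (0.48 log units; beyond the scatter) from compound 3 to compound 4, 1.8-fold (0.25 log units) apart, within the scatter of two such steps. This does not show that the step is truly the same on both cores, and two pairs say nothing about how the change would behave on any further core.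

Each pair moves the chlorine and removes the methyl group in one change, so the compounds shown leave open which of the two matters, and a plain thiophen-2-yl group at this place would separate them. Also open, as far as these compounds go, is how this place would respond to a group of another kind, such as an amine or a carboxylic acid.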